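Piperazin-1-yl replaces ethylamino in a tight cytotoxicity series

The compounds below may be only part of what the source reports. "The series", "measured", "known", "first", "only" and "open" are said of these compounds alone.

Values in a functional assay on NCI-H460 cells (Homo sapiens) for cytotoxicity, read by MTT assay, with a stated time of 3 days (on this read-out lower numbers stand for stronger inhibition and higher numbers for weaker inhibition), for the measured compounds:
Compound 1 `N#Cc1c(O)nc(SCc2nc3ccccc3[nH]2)nc1-c1ccccc1` gives 2.5 nM
Compound 2 `CCNc1nc(SCc2nc3ccccc3[nH]2)nc(-c2ccccc2)c1C#N` gives 2.87 nM
Compound 3 `N#Cc1c(Nc2nccs2)nc(SCc2nc3ccccc3[nH]2)nc1-c1ccccc1` gives 3.37 nM

On these numbers compound 2 is not separated from the other two, with a 1.1-fold higher number from compound 1 to compound 2 (0.06 log units; within the scatter) on one side and a 1.2-fold higher number from compound 2 to compound 3 (0.07 log units; within the scatter) on the other side.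

Compound 4 `N#Cc1c(-c2ccccc2)nc(SCc2nc3ccccc3[nH]2)nc1N1CCNCC1` keeps the core of compound 2 but carries piperazin-1-yl in place of ethylamino on an aromatic carbon, ortho to a cyano group piperazin-1-yl in place of ethylamino on an aromatic carbon and nothing else differs.

The measured steps that bear on this change all fall at the same place. Ethylamino in place of hydroxy gave a 1.1-fold higher number from compound 1 to compound 2 (0.06 log units; within the scatter) and (1,3-thiazol-2-yl)amino in place of hydroxy gave a 1.3-fold higher number from compound 1 to compound 3 (0.13 log units; within the scatter) while 1,3-thiazol-2-yl in place of ethyl on the nitrogen gave a 1.2-fold higher number from compound 2 to compound 3 (0.07 log units; within the scatter) as the remaining step. All three lie within the scatter. In this assay no step beyond the scatter is therefore expected, in either direction. Among the compounds with values here, none of the measured compounds has a non-aromatic ring at this place, so the expectation stays uncertain and the range is kept wide.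

For compound 4 the estimated step is a 1.0-fold higher number from compound 2 to compound 4 (0.02 log units; within the scatter) in size. Compound 4 is expected at 3 nM with an estimated range from 1.2 nM to 9 nM around that figure.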

Compound 4, half-maximal inhibitory concentration: 7.35 nM
For compound 4 the middle estimate is 2.5-fold (0.39 log units) below the measured one; the measured number falls inside the stated range.
By their numbers in this assay, from the lowest: compounds 1, 2 and 3 (each within the scatter of the next); then compound 4.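

In this assay, within the data shown here, hydroxy, ethylamino and (1,3-thiazol-2-yl)amino on this aromatic carbon, ortho to a cyano group, could not be told apart, but piperazin-1-yl gives the first steps beyond the scatter at this place (a 2.6-fold higher number from compound 2 to compound 4 (0.41 log units; beyond the scatter); a 2.2-fold higher number from compound 3 to compound 4 (0.34 log units; beyond the scatter); a 2.9-fold higher number from compound 1 to compound 4 (0.47 log units; beyond the scatter)). Among these compounds, all three steps are modest and point the same way, so the position is not indifferent to the group it carries, and compound 4, the only compound here with a six-membered non-aromatic ring at this place, stands apart from compounds 1, 2 and 3. Nothing else measured on these compounds bears on this shift.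

The compounds shown leave open whether the higher number follows the non-aromatic ring itself or its second nitrogen, a question that a morpholin-4-yl, piperidin-1-yl or 4-methylpiperazin-1-yl group at this place would address. They also leave open whether an open-chain group, such as a longer chain like butylamino or a 2-aminoethylamino group, stays with compounds 1, 2 and 3 or moves towards compound 4.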